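Compound 3: a non-aromatic ring enters the series

The compounds below may be only part of what the source reports. "The series", "measured", "known", "first", "only" and "open" are said of these compounds alone.

Among the measured compounds shown here, in a functional assay (plasma) for inhibition, with Homo sapiens as the target (a lower number here means a stronger inhibitor, a higher number a weaker inhibitor), compound 1 (`NCc1ccc(Cn2cnc3cc(C(=O)NCCC(=O)O)ccc32)cc1`) gives 83000 nM while compound 2 (`N=C(N)c1ccc(Cn2cnc3cc(C(=O)NCCC(=O)O)ccc32)cc1`) gives 6800 nM as the lowest of the two numbers so far. Compound 3 (`O=C(O)CCNC(=O)c1ccc2c(c1)ncn2CCCC1CCNCC1`), not yet measured, differs from compound 2 by a group of 8 heavy atoms (7 carbon, 1 nitrogen; one six-membered non-aromatic ring with 1 hetero atom) in place of a group of 9 heavy atoms (7 carbon, 2 nitrogen; one six-membered aromatic ring of carbon only), on a saturated chain carbon bound to an aromatic nitrogen and carries 2-(piperidin-4-yl)ethyl. For the measured compounds named here, one measured step bears on this change. It is a 12-fold lower number from compound 1 to compound 2 (1.09 log units; beyond the scatter) and it is large, so a change in this part of the molecule can move the number a long way. That step replaced only a small group on an aromatic carbon, whereas here a whole ring leaves, so it gives no firm direction. In this assay no step beyond the scatter is expected, though the margin is wide on both sides. The estimated move is a 1.4-fold lower number from compound 2 to compound 3 (0.13 log units; within the scatter) at the middle of the range. For compound 3 the estimated value is 5000 nM with an expected range from 800 nM to 30000 nM around it.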

Compound 3, half-maximal inhibitory concentration: 16000 nM
Beside the measured number, compound 3's estimate is 3.2-fold (0.51 log units) below it; measured number inside the range.
By their numbers in this assay, from the lowest: compound 2; then compound 3; then compound 1.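

In this assay, the saturated chain carbon bound to an aromatic nitrogen now tolerates a non-aromatic ring, and the step can go either way depending on the comparison. 2-(Piperidin-4-yl)ethyl loses ground against the group of compound 2 (a 2.4-fold higher number from compound 2 to compound 3 (0.37 log units; beyond the scatter)) but gains against 4-(aminomethyl)phenyl (a 5.2-fold lower number from compound 1 to compound 3 (0.71 log units; beyond the scatter)), so the two groups with an aromatic ring fall on either side of it and ring type alone does not set the order. No evidence at hand accounts for this order.

Ring and chain change together in both steps, so their separate shares remain unknown. The compounds shown also leave open how a cyclohexyl ring in place of the piperidine, or a methyl group on the piperidine nitrogen, would read in this assay.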